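Bromo to iodo on the amino series

This account rests on a few compounds, and the source may have more. Where it says the series, first, only, none or still open, it means among the compounds named here.

In a functional assay on MOLT-4 cells (Homo sapiens) for antiproliferative activity, with a stated time of 48 h (on this read-out lower numbers stand for stronger inhibition and higher numbers for weaker inhibition), compound 3 (`Nc1ccc(/C=C/C(=O)c2ccc(Br)cc2)cc1`) gives 10000 nM, level with compound 2 (`Nc1ccc(/C=C/C(=O)c2ccccc2)cc1`) at 10000 nM. Together these are the highest of the three numbers, and compound 1 (`C=C(Br)C(=O)Nc1ccc(/C=C/C(=O)c2ccc(I)cc2)cc1`) stands lower at 2800 nM. Compound 4 (`Nc1ccc(/C=C/C(=O)c2ccc(I)cc2)cc1`) is the next analogue: iodo in place of bromo on an aromatic carbon, para to a large group. Within the data shown here, the one measured step bearing on this change is no change at the digits printed from compound 2 to compound 3 (within the scatter), with bromo in place of hydrogen on an aromatic carbon. That step lies within the scatter, so no change beyond the scatter is expected here. The estimated step is a 1.1-fold lower number from compound 3 to compound 4 (0.05 log units; within the scatter). For compound 4 the expected value is 9000 nM, with an estimated range of 4000 nM to 20000 nM.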

Compound 4, half-maximal inhibitory concentration: 7500 nM
The estimate for compound 4 lay 1.2-fold (0.08 log units) above the measured number; low and high end bracket the measured number.
By their numbers in this assay, from the lowest: compound 1; then compounds 4, 2 and 3 (each within the scatter of the next).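

At the aromatic carbon para to a large group, hydrogen, bromo and iodo do not separate, with a 1.3-fold lower number from compound 2 to compound 4 (0.12 log units; within the scatter) and a 1.3-fold lower number from compound 3 to compound 4 (0.12 log units; within the scatter). Among these compounds, with iodo held fixed, the only step here beyond the scatter comes from the nitrogen: a 2.7-fold higher number from compound 1 to compound 4 (0.43 log units; beyond the scatter), with hydrogen in place of (1-bromoethenyl)carbonyl. No available data account for these numbers. As far as these compounds go, whether methoxy or nitrile at the aromatic position would depart from the halogens remains open. So does whether (1-bromoethenyl)carbonyl on the nitrogen gives a similar step alongside bromo or hydrogen.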